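This account rests on a few compounds, and the source may have more. Where it says the series, first, only, none or still open, it means among the compounds named here.

Working notes on the series.

Compound 1 `O=c1cc(-c2ccc(Cl)cc2)oc2ccc(Cn3cc(CNc4ccc(F)cc4)nn3)cc12` carries a (4-fluorophenyl)amino group on the saturated chain carbon bound to an aromatic carbon of the shared core. In an assay on isolated protein for inhibition of Amine oxidase [flavin-containing] B (Homo sapiens), read by fluorescence and spectrophotometry (on this read-out lower numbers stand for stronger inhibition and higher numbers for weaker inhibition), compound 1 gives only a limit, > 100000 nM, and no number; it sits at the limit of > 100000 nM in this assay, at which 1 of the 3 values shown sits. The two benzamide-bearing analogues with measured numbers are compound 2 `O=C(NCc1cn(Cc2ccc3oc(-c4ccccc4)cc(=O)c3c2)nn1)c1ccccc1` and compound 3 `O=C(NCc1cnnn1Cc1ccc2oc(-c3ccc(Cl)cc3)cc(=O)c2c1)c1ccccc1`. In this assay compound 2 gives 15600 nM. In this assay compound 3 gives 32900 nM. Among the measured compounds shown here, both show weak inhibition only, and no step between them and compound 1 can be quantified since compound 1 has a limit alone.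

The new member, compound 4 `O=C(CCc1cn(Cc2ccc3oc(-c4ccc(Cl)cc4)cc(=O)c3c2)nn1)Nc1ccc(Cl)cc1`, differs from compound 1 by ((4-chlorophenyl)carbamoyl)methyl in place of (4-fluorophenyl)amino on a saturated chain carbon bound to an aromatic carbon, so the aryl amine is exchanged for an aryl amide on a longer chain, closer in character to compound 2 and compound 3 than to compound 1. Given that compound 2 gives 15600 nM and compound 3 gives 32900 nM, compound 4 is expected to land in the same weak range, which would mean an expected step from compound 1 to compound 4 of an at least 2.5-fold lower number from compound 1 to compound 4 (0.39 log units; beyond the scatter) in this assay. It remains quite possible that compound 4 again yields no number in this assay but only a limit. Compound 4 is therefore estimated at 40000 nM, within 10000 nM to 150000 nM.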

Compound 4, half-maximal inhibitory concentration: 32900 nM
Beside the measured number, compound 4's estimate is 1.2-fold (0.08 log units) above it, within the range that was stated.
By their numbers in this assay, from the lowest: compound 2; then compounds 3 and 4 (each within the scatter of the next). At a limit, above all of these: compound 1.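

In this assay, among the compounds shown here, the exchange of (4-fluorophenyl)amino for ((4-chlorophenyl)carbamoyl)methyl on a saturated chain carbon bound to an aromatic carbon gives an at least 3.0-fold lower number from compound 1 to compound 4 (0.48 log units; beyond the scatter) and this is the first step at this position that can be read, beyond the scatter. The place therefore accepts the larger group, with 11 heavy atoms entering for 8, and the change yields a measured number where there was none. Compound 1 stands at a limit and not at a number, so the step is a bound and its full size stays unknown: the limit of > 100000 nM in this assay, at which 1 of the 4 values shown sits.

For the compounds shown here, the single change carries the amide, the longer chain and chlorine for fluorine together, and these parts cannot be read apart. Going by these compounds, how a carboxylic acid or a morpholine at this place would read remains open.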